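A few compounds are considered here, and "the series" means these few. Any claim that something is new, unique, unknown or untested is made for them only; others in the source may bear on it.

Measured so far:
- compound 1, `CC(C)Cn1c(=O)c2nc(-c3cnn(Cc4cccc(F)c4)c3)[nH]c2n(CC(C)C)c1=O`: 990 nM
- compound 2, `CCCn1c(=O)c2nc(-c3cnn(Cc4cc(C(F)(F)F)ccc4Cl)c3)[nH]c2n(CCC)c1=O`: 22 nM

The read-out is an in vitro assay on HEK293 cells for displacement of a labelled ligand from adenosine receptor A2b (Homo sapiens); a higher number here means a weaker inhibitor, a lower number a stronger inhibitor. Compound 1 gives 990 nM in this assay, and compound 2 gives 22 nM. Compound 2 thus holds the lower of the two numbers, and its distance from compound 1 lies beyond the usual scatter. The two differ in several places at once, so the numbers alone do not show which part of the change carries the gain.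

Compound 3 is `CCCn1c(=O)c2nc(-c3cnn(Cc4cc(F)ccc4Cl)c3)[nH]c2n(CCC)c1=O` and has not yet been tested. It keeps everything of compound 2 except one group on the outer ring: fluoro in place of trifluoromethyl on an aromatic carbon. For the measured compounds named here, no measured pair shows this particular exchange, so its effect must be guessed. Since compound 2 gives 22 nM with the larger group in place, a modest loss on trimming it down seems the likelier outcome, though a step within the scatter cannot be excluded. The expected step is a 2.7-fold higher number from compound 2 to compound 3 (0.44 log units; beyond the scatter). For compound 3 the estimated value is 60 nM, within a range from 15 nM to 250 nM.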

Compound 3, inhibition constant: 4800 nM
For compound 3 the middle estimate is 80-fold (1.90 log units) below the measured one, outside the stated range (above it).
By their numbers in this assay, from the lowest: compound 2; then compound 1; then compound 3.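

In this assay the exchange of trifluoromethyl for fluoro is a large change, with a 220-fold higher number from compound 2 to compound 3 (2.34 log units; beyond the scatter) for this single replacement on the outer ring. The group on this aromatic carbon, para to a chloro group, therefore has a strong bearing on the number, something the earlier pair could not reveal, as compound 1 and compound 2 differ in several places at once. For the compounds shown here, no measurement at hand says why this one exchange moves the number so far.

As far as these compounds go, with only trifluoromethyl and fluoro seen on this carbon, it remains open whether a methyl, a methoxy or a nitrile group would give a number close to that of compound 2, close to that of compound 3, or somewhere in between. Also open, from the compounds shown here alone, is whether the same exchange would have a step of similar size with a group other than chloro on the outer ring, or with different chains on the shared core.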